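A few compounds are considered here, and "the series" means these few. Any claim that something is new, unique, unknown or untested is made for them only; others in the source may bear on it.

In a functional assay on K562 cells (Homo sapiens) for cytotoxicity, read by ELISA, with a stated time of 4 days (on this read-out lower numbers stand for stronger inhibition and higher numbers for weaker inhibition), compound 1 `Cc1ccc(-c2cc(-c3ccoc3)cc(-c3ccc(Cl)s3)n2)cc1` gives 17900 nM, and compound 2 `Clc1ccc(-c2cc(-c3ccoc3)cc(-c3cccnc3)n2)s1` gives 18700 nM. Within the data shown here, these are the only two measured values, and they lie within the scatter of each other, so compound 1 cannot be separated from its sole neighbour on this assay.

Compound 3 `Cc1ccc(-c2cc(-c3ccc(Cl)o3)cc(-c3ccc(Cl)s3)n2)cc1` keeps the 4-methylphenyl and 5-chlorothiophen-2-yl groups of compound 1. It differs at the position opposite the ring nitrogen, where 5-chlorofuran-2-yl stands in place of furan-3-yl on an aromatic carbon: 5-chlorofuran-2-yl in place of furan-3-yl on an aromatic carbon.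

Among the measured compounds shown here, the one measured step, a 1.0-fold higher number from compound 1 to compound 2 (0.02 log units; within the scatter), exchanges 4-methylphenyl for pyridin-3-yl at another place and stays within the scatter. It shows that one change elsewhere on the core left the number in place, but it says nothing directly about the furan-3-yl position. For the measured compounds named here, no measured compound tests a change there, so the range has to stay wide.

Only a small move towards a lower number, not beyond the scatter, is expected, and the estimated step is a 1.3-fold lower number from compound 1 to compound 3 (0.11 log units; within the scatter). Compound 3 is expected at about 14000 nM, with an estimated range of 5000 nM to 35000 nM.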

Compound 3, half-maximal inhibitory concentration: 21400 nM
Beside the measured number, compound 3's estimate is 1.5-fold (0.18 log units) below it, within the range that was stated.
By their numbers in this assay, from the lowest: compounds 1, 2 and 3 (each within the scatter of the next).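

In this assay, the position opposite the ring nitrogen is now tested directly, and 5-chlorofuran-2-yl in place of furan-3-yl gives a 1.2-fold higher number from compound 1 to compound 3 (0.08 log units; within the scatter), so this exchange does not separate the two compounds. The exchange alters two things at once, the added chlorine and the ring's point of attachment, and neither effect can be read alone; all that can be said is that this pair of changes, taken together, leaves no difference beyond the scatter. Nothing measured here accounts for this result.

The compounds shown carry only a five-membered aromatic ring with one hetero atom at this position, so it remains open whether a quite different group there, such as an amine, a carboxylic acid or a longer alkyl chain, would move the number beyond the scatter. Going by these compounds, it is also open whether furan-2-yl without the chlorine would match either compound, and whether 5-chlorofuran-2-yl would give the same result alongside the pyridin-3-yl group of compound 2.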